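Chain shortening in the (2-aminophenyl)carbamoyl series

This account rests on a few compounds, and the source may have more. Where it says the series, first, only, none or still open, it means among the compounds named here.

Measured in a functional assay on MCF7 cells (Homo sapiens) for antiproliferative activity, read by CCK-8 assay, with a stated time of 72 h; a lower number here means a stronger inhibitor, a higher number a weaker inhibitor:
- compound 1 `CCOc1cc(C(C)(C)C)ccc1C1=NC(c2ccc(Cl)cc2)C(c2ccc(Cl)cc2)N1C(=O)NCCCCCCCC(=O)Nc1ccccc1N`: 20300 nM
- compound 2 `CCOc1cc(C(C)(C)C)ccc1C1=NC(c2ccc(Cl)cc2)C(c2ccc(Cl)cc2)N1C(=O)NCCCCCCC(=O)Nc1ccccc1N`: > 100000 nM (a limit)

Compound 2 reads > 100000 nM, which is a limit of the assay and not a number. Compound 3 `CCOc1cc(C(C)(C)C)ccc1C1=NC(c2ccc(Cl)cc2)C(c2ccc(Cl)cc2)N1C(=O)NCCCCC(=O)Nc1ccccc1N` has (2-aminophenyl)carbamoyl in place of 2-((2-aminophenyl)carbamoyl)ethyl on a saturated chain carbon, four bonds along the chain from an amide-type nitrogen. Among the compounds with values here, the one measured step bearing on this is an at least 4.9-fold higher number from compound 1 to compound 2 (0.69 log units; beyond the scatter), a shortening of the same chain, and it lies beyond the scatter. Going by these compounds, its true size stays open, so a number no lower than that limit is expected in this assay, most likely again a limit. The expected step is a step that the limit leaves unreadable from compound 2 to compound 3. Compound 3 is estimated at 120000 nM, with an expected range of 40000 nM to 300000 nM.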

Compound 3, half-maximal inhibitory concentration: 29100 nM
Beside the measured number, compound 3's estimate is 4.1-fold (0.62 log units) above it; measured number outside the range, below it.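

In this assay, shortening this chain does not push the read-out in one direction: the change gives an at least 3.4-fold lower number from compound 2 to compound 3 (0.53 log units; beyond the scatter), opposite in sign to the earlier shortening. Compound 3, with the shortest chain shown, still returns a measured 29100 nM. The value of compound 2, > 100000 nM, is a limit and not a number, and the true size of the step stays open: the limit of > 100000 nM in this assay, at which 1 of the 3 values shown sits.

Still open, going by these compounds, is whether a longer chain than in compound 1, or a shorter one than in compound 3, continues this uneven course. Also open, on these data alone, is how a hydroxamic acid in place of the (2-aminophenyl)carbamoyl group would read at this position.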